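Swapping Trifluoromethyl for Chloro on the Sulfonyl Arene

The source may report more compounds than this note shows. Statements on the series, on what has been measured and on what is new or still open speak of the compounds shown alone.

Measured compounds:
Compound 1, `Nc1nc2c(c(=O)n(CC3CC3)c(=O)n2CC2CC2)n1Cc1ccc([N+](=O)[O-])cc1`: 30%
Compound 2, `Nc1nc2c(c(=O)n(CC3CC3)c(=O)n2CC2CC2)n1S(=O)(=O)c1ccc(C(F)(F)F)cc1`: 0%

Both compounds were tested in an assay on isolated protein with dual specificity calcium/calmodulin-dependent 3',5'-cyclic nucleotide phosphodiesterase 1B (Bos taurus) as the target, tested at 100 uM; a lower number here means less inhibition, a higher number more inhibition at the concentration tested (going by the name of the read-out). Among the compounds with values here, compound 1 gives 30%, while compound 2 gives 0%, and the gap between the two lies beyond the usual scatter of this kind of measurement, so compound 2 stands lowest of the two numbers measured so far.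

Compound 3, `Nc1nc2c(c(=O)n(CC3CC3)c(=O)n2CC2CC2)n1S(=O)(=O)c1ccc(Cl)cc1`, keeps everything of compound 2 except one group: chloro in place of trifluoromethyl on an aromatic carbon. Within the data shown here, no measured pair in this small set shows this same change, so there is no direct precedent for how large an effect it brings. Because compound 2 gives only 0%, the change is expected to move the number little; the step from compound 2 to compound 3 is estimated at a number 5 percentage points higher from compound 2 to compound 3 (within the scatter), a shift that would stay within the scatter. For compound 3 the expected inhibition in this assay is 5%, with a plausible range from 0% to 20%.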

Compound 3, a percentage reported as inhibition, at one concentration (the size of the read-out at that concentration, not a potency): 1%
Estimate against measurement, compound 3: 4 percentage points above; the measured number falls inside the stated range.
By their numbers in this assay, from the lowest: compounds 2 and 3 (each within the scatter of the next); then compound 1.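

Chloro and trifluoromethyl on the sulfonyl arene cannot be told apart in this assay: the change from 4-(trifluoromethyl)phenyl to 4-chlorophenyl gives a number 1 percentage points higher from compound 2 to compound 3 (within the scatter). The larger replacement on the aromatic nitrogen, (4-chlorophenyl)sulfonyl in place of 4-nitrobenzyl, gives a number 29 percentage points lower from compound 1 to compound 3 (beyond the scatter), so within these compounds the clear change goes with swapping that whole substituent and not with the choice between chloro and trifluoromethyl. Since compound 2 and compound 3 both sit near the bottom of the scale, a single test concentration offers little room to show any real difference between them.

As far as these compounds go, it remains open whether an amine or a carboxylic acid on that aromatic carbon of the sulfonyl arene would lift the number, and whether 4-chlorobenzyl on the aromatic nitrogen would stay near the level of compound 1 at 30%, which would separate the role of the sulfonyl link from that of the ring substituent. Nothing in the data shown gives a reason for either step.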